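Configuration swap in the bromo sulfonamide series

This account rests on a few compounds, and the source may have more. Where it says the series, first, only, none or still open, it means among the compounds named here.

Compound 1 `NC(=O)c1[nH]c2ccc(Br)cc2c1S(=O)(=O)N1CCCC1`: 35300 nM
Compound 2 `C=CC(=O)N1CC[C@@H](NS(=O)(=O)c2c(C(N)=O)[nH]c3ccc(Br)cc23)C1`: 51800 nM
Compound 3 `C=CC(=O)N[C@@H]1CCN(S(=O)(=O)c2c(C(N)=O)[nH]c3ccc(Br)cc23)C1`: 178000 nM

All three values come from an ADME assay on MT4 cells (Homo sapiens) for cytotoxicity, read by MTT assay, with a stated time of 5 days; a higher number here means that more compound is tolerated, a lower number that less compound is tolerated. Compound 2 lies within the scatter of compound 1, and the value of compound 3 stands clearly higher than both.

Compound 4 `C=CC(=O)N1CC[C@H](NS(=O)(=O)c2c(C(N)=O)[nH]c3ccc(Br)cc23)C1` is the next compound to read against compound 2: the two compounds have the same atoms and bonds and differ only in configuration as drawn: 1 of 1 stereo elements differ; a stereocentre at a saturated ring carbon is drawn R in compound 2 and S in compound 4. Nothing leaves and nothing enters. A stereocentre at a saturated ring carbon is drawn R in compound 2 and S in compound 4.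

Going by the values given here, the only measured step between neighbours, a 5.0-fold higher number from compound 1 to compound 3 (0.70 log units; beyond the scatter), is modest and reflects a different change, (vinylcarbonyl)amino in place of hydrogen on a saturated ring carbon. Among the compounds with values here, no measured pair differs in configuration alone, so the data give no direct size for this swap. In this assay, no step beyond the scatter is therefore expected, in either direction, although this rests on thin evidence.

The expected step is a 1.1-fold higher number from compound 2 to compound 4 (0.03 log units; within the scatter). For compound 4 the estimated value is 55000 nM, with an expected range of 25000 nM to 120000 nM.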

Compound 4, half-maximal cytotoxic concentration: 155000 nM
The estimate for compound 4 lay 2.8-fold (0.45 log units) below the measured number, and the stated range ends below it.
By their numbers in this assay, from the lowest: compounds 1 and 2 (each within the scatter of the next); then compounds 4 and 3 (each within the scatter of the next).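

In this assay, inverting the stereocentre at the saturated ring carbon gives a 3.0-fold higher number from compound 2 to compound 4 (0.48 log units; beyond the scatter). Going by these compounds alone, this is the first measured size for a change of configuration in this bromo sulfonamide series, and it shows that configuration at this position can shift the tolerated concentration beyond the scatter without any group leaving or entering. The step can be tied to this stereocentre alone, because nothing else separates the pair: the fact that compounds 2 and 4 differ only in the configuration as drawn.

The compounds shown leave open whether the same inversion gives a step of similar size when the vinylcarbonyl group is replaced by an acetyl group or a free amine. They also leave open whether the S drawing stays the better tolerated one when the bromine on the shared core gives way to chlorine or hydrogen.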